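This account rests on a few compounds, and the source may have more. Where it says the series, first, only, none or still open, it means among the compounds named here.

Among the measured compounds shown here, in a functional assay on BXPC-3 cells (Homo sapiens) for antiproliferative activity, read by MTT assay, with a stated time of 24 h (on this read-out lower numbers stand for stronger inhibition and higher numbers for weaker inhibition), two compounds on the shared core have numbers so far. Compound 1 (`CCn1c(C(=O)N[C@H](C)CO)ccc1C(CC)(CC)c1ccc(OCS(=O)(=O)c2ccccc2)c(C)c1`) gives 10000 nM and compound 2 (`CCn1c(C(=O)N[C@@H](CO)CCCO)ccc1C(CC)(CC)c1ccc(OCS(=O)(=O)c2ccccc2)c(C)c1`) gives 16400 nM (the two lie within the scatter of each other). Compound 3 (`CCn1c(C(=O)NCC(=O)O)ccc1C(CC)(CC)c1ccc(OCS(=O)(=O)c2ccccc2)c(C)c1`) differs from compound 2 on the amide-type nitrogen (a group of 4 heavy atoms (2 carbon, 2 oxygen; no ring) in place of a group of 7 heavy atoms (5 carbon, 2 oxygen; no ring), on an amide-type nitrogen) and so carries a carboxymethyl there. For the measured compounds named here, only one measured step bears on this: a 1.6-fold higher number from compound 1 to compound 2 (0.21 log units; within the scatter) (also a change in the group on that nitrogen). Going by the values given here, this is thin evidence, and no measured compound carries a carboxymethyl. No step beyond the scatter is therefore expected in this assay and no direction is favoured. The estimate means a 1.1-fold lower number from compound 2 to compound 3 (0.04 log units; within the scatter) (an expected step only). The estimated value for compound 3 is 15000 nM (expected range 6000 nM to 38000 nM).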

Compound 3, half-maximal inhibitory concentration: > 50000 nM
Compound 3 ended at the assay's limit; the forecaster's own chance of this, stated with the estimate: 15%; middle value at least 3.3-fold (0.52 log units) away from the limit.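

Among the compounds shown here, on the amide-type nitrogen, the step from compound 1 to compound 2 gave no sign that the group there matters, whereas carboxymethyl gives the first steps beyond the scatter: an at least 3.0-fold higher number from compound 2 to compound 3 (0.48 log units; beyond the scatter) and an at least 5.0-fold higher number from compound 1 to compound 3 (0.69 log units; beyond the scatter). Among the three compounds, the two groups bearing hydroxyl stay within the scatter of each other and carboxymethyl alone stands apart, so this position does respond to the group it carries. In this assay compound 3 gives > 50000 nM, which is a limit and not a number: the limit of > 50000 nM in this assay, at which 1 of the 3 values shown sits.

The change replaces the whole group, so the compounds shown do not separate the effect of the carboxylic acid end from that of the shorter chain. A methyl ester or primary amide on the same chain, or a longer chain ending in a carboxylic acid, would bear on that question.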